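Working notes: microsomal clearance across four related compounds

A few compounds are considered here, and "the series" means these few. Any claim that something is new, unique, unknown or untested is made for them only; others in the source may bear on it.

Compound 1 `C[C@H](NC(=O)[C@@H]1CCCN1C)c1ccc(NC(=O)N2CC(c3ccc(N)nc3)C2)cc1` and compound 3 `C[C@H](NC(=O)[C@@H]1CCCN1C)c1ccc(NC(=O)N2CC(c3cncc(N)c3)C2)cc1` are built from the same atoms joined differently; the difference between the two cores is 5-aminopyridin-3-yl in place of 6-aminopyridin-3-yl on a saturated ring carbon. In an ADME assay on microsomes from liver (Mus musculus) for pharmacokinetics, read by LC-MS, using NADPH, with stated times of 5 min, 15 min and 30 min, tested at 10 uM (a lower number here means slower removal, a higher number faster removal of the compound), compound 1 gives only a limit, < 25 mL.min-1.g-1. Compound 3 gives 47.4 mL.min-1.g-1 in this assay, and the step is an at least 1.8-fold higher number from compound 1 to compound 3 (0.27 log units; that floor lies within the scatter). Compound 2 `CCC(=O)N[C@@H](C)c1ccc(NC(=O)N2CC(c3ccc(N)nc3)C2)cc1` differs from compound 1 by ethyl in place of 1-methylpyrrolidin-2-yl on a carbonyl carbon; in this assay compound 2 gives 22 mL.min-1.g-1, and the step that the limit leaves unreadable from compound 1 to compound 2 cannot be sized because of the limit of < 25 mL.min-1.g-1 in this assay, at which 1 of the 3 values shown sits. Compound 4 `CCC(=O)N[C@@H](C)c1ccc(NC(=O)N2CC(c3cncc(N)c3)C2)cc1` is the unmeasured partner. It differs from compound 3 by ethyl in place of 1-methylpyrrolidin-2-yl on a carbonyl carbon, the same change as that made from compound 1 to compound 2, with the place described in identical words. Within the data shown here, what is known of that change is only that compound 2 sits at a number while compound 1 sits at a limit, so the size and direction of the step in this assay stay open. For compound 4 a step of a 1.1-fold lower number from compound 3 to compound 4 (0.02 log units; within the scatter) is estimated. Among the measured compounds shown here, for compound 4 a value of 45 mL.min-1.g-1 is expected, spanning 20 mL.min-1.g-1 to 100 mL.min-1.g-1, because compound 2 gives 22 mL.min-1.g-1 on the core of compound 1 and because the core step an at least 1.8-fold higher number from compound 1 to compound 3 (0.27 log units; that floor lies within the scatter) is the only sized step in the set.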

Compound 4, intrinsic clearance in microsomes: 56.9 mL.min-1.g-1
For compound 4 the middle estimate is 1.3-fold (0.10 log units) below the measured one, and the stated range covers the measured number.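

In this assay, 5-aminopyridin-3-yl in place of 6-aminopyridin-3-yl on a saturated ring carbon gives a 2.6-fold higher number from compound 2 to compound 4 (0.41 log units; beyond the scatter), and set beside the other core the change reads: the same change on two cores in this assay, an at least 1.8-fold higher number (0.27 log units; that floor lies within the scatter) from compound 1 to compound 3 and a 2.6-fold higher number (0.41 log units; beyond the scatter) from compound 2 to compound 4; the limit leaves it open whether they differ

Compound 1 gives < 25 mL.min-1.g-1, which is a limit and not a number, so both steps point to a higher number, but the pairs do not show that a size carries from one core to the other. Ethyl in place of 1-methylpyrrolidin-2-yl on a carbonyl carbon gives a 1.2-fold higher number from compound 3 to compound 4 (0.08 log units; within the scatter), while the matching step on the other core cannot be read.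

The compounds shown leave open whether the core change keeps its direction with a longer chain or a primary amine on the carbonyl carbon. They also leave open how a carboxylic acid on the saturated ring carbon would compare with the two aminopyridinyl groups in this assay.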